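The source may hold more compounds than are shown below. What is called first, only, known or untested is meant among the compounds shown, and "the series" means these compounds.

Measured so far in an ADME assay on HepG2 cells (Homo sapiens) for cytotoxicity, read by MTT assay, with a stated time of 72 h; on this read-out lower numbers stand for higher toxicity in this test and higher numbers for lower toxicity in this test:
compound 1 `N/C(=N/O)c1ccc(C2=C(S(=O)(=O)c3ccc(F)cc3)CC(c3ccccc3)(c3ccccc3)O2)cc1` gives 19200 nM
compound 2 `CC1(c2ccc(-c3ccccc3C#N)cc2)CC(S(=O)(=O)c2ccc(F)cc2)=C(c2ccc(/C(N)=N\O)cc2)O1` gives 58300 nM
compound 3 `CC1(Cc2ccccc2)CC(S(=O)(=O)c2c(F)cccc2F)=C(c2ccc(/C(N)=N\O)cc2)O1` gives 91400 nM

Within this small set compound 2 has the second-highest number of the three. Its nearest neighbour is compound 3, whose number lies within the scatter of repeated measurements, so the two cannot be ordered. Compound 1 sits furthest away, with a number lower than that of compound 2 by a gap that exceeds the scatter; in this test the lower number stands for higher toxicity. Within the data shown here, no pair of measured compounds differs in only one place, so no single-step effect can be read from the numbers.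

Compound 4 `CC1(c2ccc(-c3ccncc3)cc2)CC(S(=O)(=O)c2ccc(F)cc2)=C(c2ccc(/C(N)=N\O)cc2)O1` is not yet measured. It arises from compound 2 through the change (pyridin-4-yl in place of 2-cyanophenyl on an aromatic carbon), pyridin-4-yl in place of 2-cyanophenyl on an aromatic carbon. Nothing in the measured set shows what this change does, so the expectation for compound 4 in this assay is a step of a 1.1-fold lower number from compound 2 to compound 4 (0.03 log units; within the scatter) of no size beyond the scatter, in no preferred direction. Compound 4 is therefore estimated at 55000 nM, with a range from 25000 nM to 120000 nM; the upper end reaches the region where the assay may report only a limit.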

Compound 4, half-maximal cytotoxic concentration: 30300 nM
Compound 4: middle estimate off by 1.8-fold (0.26 log units), on the high side, and the stated range covers the measured number.
By their numbers in this assay, from the lowest: compounds 1, 4, 2 and 3 (each within the scatter of the next, the first and the last beyond it).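

Among these compounds, this is the first pair that differs in one place: in this assay, pyridin-4-yl in place of 2-cyanophenyl on an aromatic carbon, para to a large group, gives a 1.9-fold lower number from compound 2 to compound 4 (0.28 log units; within the scatter) and so does not separate the two compounds. This position therefore carries either group with no step beyond the scatter, and the nitrile-bearing ring is not needed to keep compound 4 in the same range as compound 2. No measurement available here bears on why the two compounds read alike.

Going by these compounds, whether a carboxylic acid or an aminomethyl group on this aromatic carbon would give a step beyond the scatter remains open. On these data alone, with a single pair at this position, it is also open whether the same exchange would give a similar step with other groups elsewhere on the shared core.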